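The compounds below may be only part of what the source reports. "The series", "measured", "known", "first", "only" and "open" are said of these compounds alone.

Four compounds share one core and differ only in the group carried on an oxygen on a saturated carbon. Compound 1 `CC(C)[C@H](NC(=O)COc1cccc2ccccc12)C(=O)N[C@@H](CC(=O)O)C(=O)COC(=O)c1c(Cl)cccc1Cl` gives 10600 nM in a functional assay on Jurkat cells (Homo sapiens) (on this read-out lower numbers stand for stronger inhibition and higher numbers for weaker inhibition), and compound 2 `CC(C)[C@H](NC(=O)COc1cccc2ccccc12)C(=O)N[C@@H](CC(=O)O)C(=O)COc1ccc(Oc2ccc(C(F)(F)F)cc2)cc1` gives 9300 nM. Compound 3 `CC(C)[C@H](NC(=O)COc1cccc2ccccc12)C(=O)N[C@@H](CC(=O)O)C(=O)COc1ccccc1F` reaches only a limit of this assay, reported as > 100000 nM. For the measured compounds named here, the single measured step onto compound 3 is an at least 9.4-fold higher number from compound 1 to compound 3 (0.97 log units; beyond the scatter). From the compounds shown here alone, that step runs into (the limit of > 100000 nM in this assay, at which 1 of the 3 values shown sits), so its full size is unknown. Compound 4 `CC(C)[C@H](NC(=O)COc1cccc2ccccc12)C(=O)N[C@@H](CC(=O)O)C(=O)COc1c(F)c(F)cc(F)c1F` arises from compound 3 by 2,3,5,6-tetrafluorophenyl in place of 2-fluorophenyl on an oxygen on a saturated carbon. Going by the values given here, no measured step tries a change of this kind, so the expectation leans on the two numbered values, which sit close together, while compound 3 falls out of range. For compound 4 the expected step is an at least 20-fold lower number from compound 3 to compound 4 (1.30 log units; beyond the scatter), and its estimated value is 5000 nM, within a range from 800 nM to 100000 nM.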

Compound 4, half-maximal inhibitory concentration: 4500 nM
For compound 4 the middle estimate is 1.1-fold (0.05 log units) above the measured one; the range from low to high includes it.
By their numbers in this assay, from the lowest: compound 4; then compounds 2 and 1 (each within the scatter of the next). At a limit, above all of these: compound 3.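

In this assay, the group on an oxygen on a saturated carbon proves highly sensitive within the fluorophenyl series, with 2,3,5,6-tetrafluorophenyl giving a large gain over 2-fluorophenyl: an at least 22-fold lower number from compound 3 to compound 4 (1.34 log units; beyond the scatter). From the compounds shown here alone, compound 3, at > 100000 nM, sits at a limit and has no exact number, so the full size of that gain is unknown: the limit of > 100000 nM in this assay, at which 1 of the 4 values shown sits. The tetrafluorophenyl group also outperforms the (2,6-dichlorophenyl)carbonyl group, though only modestly: a 2.4-fold lower number from compound 1 to compound 4 (0.37 log units; beyond the scatter).

Still open, going by these compounds, is how a phenyl ring with two or three fluorines, or with chlorine or a nitrile in their place, would fare.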